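Para-substituent swap on a benzoyl pyrrole hydroxamate

The source may hold more compounds than are shown below. What is called first, only, known or untested is meant among the compounds shown, and "the series" means these compounds.

The measured compounds are: compound 1 `COc1ccc(C(=O)c2cc(/C=C/C(=O)NO)n(C)c2)cc1` with 1740 nM in an assay on isolated protein with histone deacetylase HD2 (Zea mays) as the target; a lower number here means a stronger inhibitor, a higher number a weaker inhibitor; compound 2 `Cn1cc(C(=O)c2ccccc2)cc1CCC(=O)NO` with 4.37 nM in this assay; compound 3 `Cn1cc(C(=O)c2ccc(Cl)cc2)cc1/C=C/C(=O)NO` with 1450 nM in this assay.

Compound 3 stands as the second highest of the three numbers. Its nearest neighbour is compound 1, whose number lies within the scatter of that of compound 3, while compound 2 sits far away with a number that is lower beyond the scatter. Compound 4 `Cn1cc(C(=O)c2ccc([N+](=O)[O-])cc2)cc1/C=C/C(=O)NO` has not yet been measured. It differs from compound 3 in one place: nitro in place of chloro on an aromatic carbon. Among the measured compounds shown here, the one measured step that bears on this change is the earlier swap of the same para group, a 1.2-fold lower number from compound 1 to compound 3 (0.08 log units; within the scatter), which stayed within the scatter. On that ground, the step from compound 3 to compound 4 is expected to be small, a 1.1-fold lower number from compound 3 to compound 4 (0.05 log units; within the scatter), in no clear direction. Compound 4 is therefore estimated at 1300 nM, with a range from 500 nM to 3500 nM.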

Compound 4, inhibition constant: 2340 nM
The estimate for compound 4 lay 1.8-fold (0.26 log units) below the measured number; low and high end bracket the measured number.
By their numbers in this assay, from the lowest: compound 2; then compounds 3, 1 and 4 (each within the scatter of the next).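

Replacing chloro with nitro, on an aromatic carbon para to a large group, gives a 1.6-fold higher number from compound 3 to compound 4 (0.21 log units; within the scatter) and, against methoxy, a 1.3-fold higher number from compound 1 to compound 4 (0.13 log units; within the scatter) in this assay and both steps stay within the scatter. A group of 3 heavy atoms with 2 hydrogen-bond acceptors thus leaves the number as unresolved from those of compound 1 and compound 3 as the earlier methoxy-to-chloro swap did, so the three groups at this place cannot be ranked. No evidence at hand speaks to what lies behind these numbers.

As far as these compounds go, whether an amine or a carboxylic acid at this place would move the number beyond the scatter stays open. So does whether chloro, methoxy or nitro would behave the same way on the core of compound 2.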